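Taking the methyl off compound 2

The source may report more compounds than this note shows. Statements on the series, on what has been measured and on what is new or still open speak of the compounds shown alone.

Measured so far in a functional assay on NCI-H2228 cells (Homo sapiens) for inhibition, read by CellTiter-Glo, with a stated time of 96 h (on this read-out higher numbers stand for weaker inhibition and lower numbers for stronger inhibition), by compound
compound 1 (`CC(C)S(=O)(=O)c1nn(C)cc1Nc1nc(Nc2ccc(C3CCN(C)CC3)cc2OC2CC2)ncc1Cl`) with 36 nM
compound 2 (`Cc1cc(Nc2ncc(Cl)c(Nc3cn(C)nc3S(=O)(=O)C(C)C)n2)c(OC(C)C)cc1C1CCN(C)C1`) with 131 nM
compound 3 (`Cc1cc(Nc2ncc(Cl)c(Nc3cn(C)nc3S(=O)(=O)C(C)C)n2)c(OC2CC2)cc1C1CCCN(C)C1`) with 32 nM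

Compound 2 has the highest number of the three, which makes it the weakest inhibitor here, and its gaps to compound 1 and compound 3 both lie beyond the scatter. Compound 4 (`Cc1cc(Nc2ncc(Cl)c(Nc3cn(C)nc3S(=O)(=O)C(C)C)n2)c(OC(C)C)cc1C1CCNC1`) carries hydrogen in place of methyl on an amine nitrogen in a ring, changing 1-methylpyrrolidin-3-yl to pyrrolidin-3-yl (hydrogen in place of methyl on an amine nitrogen in a ring). Within the data shown here, no measured pair shows this change, so its size is unknown. No step beyond the scatter is expected in this assay, and neither direction is favoured. The estimated step (a 1.1-fold lower number from compound 2 to compound 4 (0.04 log units; within the scatter)) is correspondingly small. For compound 4 the expected value is 120 nM, within an estimated range from 45 nM to 320 nM.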

Compound 4, half-maximal inhibitory concentration: 364 nM
Compound 4: middle estimate off by 3.0-fold (0.48 log units), on the low side; the whole stated range lies below it.
By their numbers in this assay, from the lowest: compounds 3 and 1 (each within the scatter of the next); then compound 2; then compound 4.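

In this assay, the methyl on the amine nitrogen of the 1-methylpyrrolidin-3-yl group matters: replacing it with hydrogen gives a 2.8-fold higher number from compound 2 to compound 4 (0.44 log units; beyond the scatter) and so weaker inhibition. Among these compounds, this is the first pair in the set that differs in one place, and it shows that this nitrogen is not indifferent to what it carries. Nothing measured here explains the rise. From the compounds shown here alone, whether an ethyl or acetyl group on this nitrogen would give a lower or higher number stays open. So does whether the same swap would act alike on the amine rings of compound 1 and compound 3.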